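A few compounds are considered here, and "the series" means these few. Any claim that something is new, unique, unknown or untested is made for them only; others in the source may bear on it.

Compound 1 `COc1ccc(/C=C2\CCC=CC2=O)cc1` and compound 2 `COc1cccc(/C=C2\CCC=CC2=O)c1` share the same core and each carries a methoxy group on the aromatic ring. In a functional assay on A549 cells (Homo sapiens) for antiproliferative activity, read by sulforhodamine B assay, with a stated time of 72 h (on this read-out higher numbers stand for weaker inhibition and lower numbers for stronger inhibition), compound 1 gives 1460 nM, and compound 2 gives 1480 nM. Compound 1 has the lower of the two numbers, but its gap to compound 2 lies within the scatter of repeated measurements, so the two compounds cannot be ranked on these data.

Compound 3 `O=C1C=CCC/C1=C\c1ccc(OC(F)(F)F)cc1` has not been measured yet. Against compound 1 it carries a single change: trifluoromethyl in place of methyl on an oxygen on an aromatic ring. Within the data shown here, no measured pair here shows this exchange, so there is no earlier step to lean on. In this assay the step from compound 1 to compound 3 is expected to be small, with no clear direction and probably not beyond the scatter. Compound 3 is estimated at 1500 nM, within a range from 500 nM to 4500 nM, which means an expected step of a 1.0-fold higher number from compound 1 to compound 3 (0.01 log units; within the scatter).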

Compound 3, half-maximal inhibitory concentration: 440 nM
For compound 3 the middle estimate is 3.4-fold (0.53 log units) above the measured one; measured number below the stated range.
By their numbers in this assay, from the lowest: compound 3; then compounds 1 and 2 (each within the scatter of the next).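

Replacing methyl with trifluoromethyl on the oxygen gives, in this assay, a 3.3-fold lower number from compound 1 to compound 3 (0.52 log units; beyond the scatter), so the number responds to what this oxygen carries on the aromatic ring. Compound 1 and compound 2 could not show this, as both carry a methoxy group and neither changes the group on that oxygen. No measurement here explains the stronger inhibition of compound 3, so the step stands as an observation without a known cause.

This single exchange leaves open whether the oxygen tolerates other groups, such as a longer chain like ethyl or butyl, or whether a free hydroxyl or an amine would do as well. It also leaves open whether the same exchange in compound 2 would give a step of similar size.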